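The compounds below may be only part of what the source reports. "The series", "measured", "known", "first", "only" and "open" are said of these compounds alone.

Three compounds share one core. For compound 1 `CC(C)[C@@H](NC(=O)/C=C/c1ccncc1-c1ccc2ccccc2c1)C(=O)O` the entry in a functional assay on HCT-116 cells (Homo sapiens) for inhibition, read by MTT assay, with a stated time of 72 h (on this read-out lower numbers stand for stronger inhibition of growth and higher numbers for weaker inhibition of growth), reads "not determined" (no result reported). In this assay compound 2 `CNC(=O)/C=C/c1ccncc1-c1ccc2ccccc2c1` gives 6550 nM, and compound 3 `O=C(/C=C/c1ccncc1-c1ccc2ccccc2c1)NC1CC1` gives 6180 nM. Going by the values given here, the single step between them, a 1.1-fold lower number from compound 2 to compound 3 (0.03 log units; within the scatter), places compound 3 alongside compound 2 inside the scatter, and compound 2 is the only other compound with a number. Compound 4 `CN1CCN(C(=O)/C=C/c2ccncc2-c2ccc3ccccc3c2)CC1` differs from compound 3 in one place: 4-methylpiperazin-1-yl in place of cyclopropylamino on a carbonyl carbon. Among the compounds with values here, the only measured step at the same part of the molecule, a 1.1-fold lower number from compound 2 to compound 3 (0.03 log units; within the scatter), exchanged one substituent on the amide-type nitrogen for another and stayed within the scatter. That step does not cover the loss of the amide hydrogen or the entry of 4-methylpiperazin-1-yl, so the present data give no ground for a large shift in either direction. Compound 4 is therefore expected to give about 7000 nM, within 3000 nM to 18000 nM, a step of a 1.1-fold higher number from compound 3 to compound 4 (0.05 log units; within the scatter) that is expected to remain within the scatter.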

Compound 4, concentration for 50% growth inhibition: > 30000 nM
Compound 4: only a limit was reported (the forecaster's own chance of this, stated with the estimate: 10%); middle value at least 4.2-fold (0.63 log units) from the limit.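

Up to this point, the only change at the carbonyl carbon was a swap of substituent on the amide-type nitrogen, which stayed within the scatter; here, in this assay, the same position shows that it can shift the read-out. Putting 4-methylpiperazin-1-yl in place of cyclopropylamino gives an at least 4.8-fold higher number from compound 3 to compound 4 (0.68 log units; beyond the scatter), and putting it in place of methylamino gives an at least 4.5-fold higher number from compound 2 to compound 4 (0.66 log units; beyond the scatter), both beyond the scatter and both towards weaker inhibition of growth. The entry for compound 4 is a limit and not a number, and both steps are therefore minimum sizes: the limit of > 30000 nM in this assay, at which 1 of the 4 values shown sits.

No compound shown separates the loss of the amide hydrogen from the entry of the 4-methylpiperazin-1-yl ring, and a dimethylamino or morpholin-4-yl group on the same carbonyl carbon would bear on that question. On these data alone, how far the growth inhibition falls beyond the limit also remains open.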